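Chloro Addition on the Trifluoromethylphenyl Urea Terminus

The source may hold more compounds than are shown below. What is called first, only, known or untested is meant among the compounds shown, and "the series" means these compounds.

Compound 1 `O=C(Nc1cccc(-n2cc(-c3ccncc3)c(-c3ccc(Cl)c(O)c3)n2)c1)Nc1cccc(C(F)(F)F)c1` reaches only a limit in a functional assay on NCI-H322M cells (Homo sapiens) for inhibition, read by sulforhodamine B assay, with a stated time of 48 h (on this read-out lower numbers stand for stronger inhibition of growth and higher numbers for weaker inhibition of growth), reported as > 32500 nM. Compound 2 `O=C(Nc1cccc(-n2cc(-c3ccncc3)c(-c3ccc(Cl)c(O)c3)n2)c1)Nc1cc(C(F)(F)F)cc(C(F)(F)F)c1` gives 5390 nM in this assay. Among the compounds with values here, the single measured step, an at least 6.0-fold lower number from compound 1 to compound 2 (0.78 log units; beyond the scatter), shows that a second ring substituent moves the number off the limit (the limit of > 32500 nM in this assay, at which 1 of the 2 values shown sits). Compound 3 `O=C(Nc1cccc(-n2cc(-c3ccncc3)c(-c3ccc(Cl)c(O)c3)n2)c1)Nc1ccc(Cl)c(C(F)(F)F)c1` differs from compound 1 by chloro in place of hydrogen on an aromatic carbon. Because an at least 6.0-fold lower number from compound 1 to compound 2 (0.78 log units; beyond the scatter) ran downward with an added substituent, a smaller step in the same direction is expected for compound 3, an at least 2.7-fold lower number from compound 1 to compound 3 (0.43 log units; beyond the scatter). Compound 3 is therefore estimated at 12000 nM, with a range of 3500 nM to 40000 nM in this assay, and a real chance of another limit.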

Compound 3, concentration for total growth inhibition: 4480 nM
Beside the measured number, compound 3's estimate is 2.7-fold (0.43 log units) above it, within the range that was stated.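

Chloro in place of hydrogen on the 3-(trifluoromethyl)phenyl ring, ortho to the trifluoromethyl group and para to a large group, gives an at least 7.2-fold lower number from compound 1 to compound 3 (0.86 log units; beyond the scatter) in this assay. A second ring substituent on this terminus therefore moves the number off the limit with chloro as well as with trifluoromethyl. Compound 1 stands at a limit, so the step has a floor and no exact size: the limit of > 32500 nM in this assay, at which 1 of the 3 values shown sits.

On these data alone, whether an amine, a methoxy group or a carboxylic acid at this position also moves the number off the limit remains open. Also open, as far as these compounds go, is what chloro does on this ring without the trifluoromethyl group.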